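Swapping a piperidine for an acetamide on the aniline ring

The source may hold more compounds than are shown below. What is called first, only, known or untested is meant among the compounds shown, and "the series" means these compounds.

The series shares one core, seen in compound 1 `CC1CCN(c2ccc(Nc3nccc(-c4cccnc4)n3)cc2)CC1`, compound 2 `CC1CCN(c2ccc(Nc3nccc(-c4cccs4)n3)cc2)CC1` and compound 3 `CC(=O)Nc1cccc(Nc2nccc(-c3ccccn3)n2)c1`. In a functional assay for inhibition, with Homo sapiens as the target (on this read-out lower numbers stand for stronger inhibition and higher numbers for weaker inhibition), compound 1 gives 500 nM, compound 2 gives 400 nM and compound 3 gives 300 nM. Compound 1 thus has the highest number of the three, but all three values lie within the scatter of one another, so no order among them can be read from these data.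

Compound 4 `CC(=O)N(C)c1ccc(Nc2nccc(-c3cccnc3)n2)cc1` is not yet measured. It differs from compound 1 in one place: acetyl(methyl)amino in place of 4-methylpiperidin-1-yl on an aromatic carbon. Within the data shown here, only one measured step is available, a 1.3-fold lower number from compound 1 to compound 2 (0.10 log units; within the scatter), and it changes a different part of the molecule, so it bears on the new step only loosely. Compound 3 carries a related acetamide-type group and gives a number close to that of compound 1, which suggests that such a group on the aniline ring is tolerated, though compound 3 also differs from compound 4 elsewhere. The step of no change at the digits printed from compound 1 to compound 4 (within the scatter) is therefore expected to stay within the scatter. Compound 4 is estimated at 500 nM, with a likely range from 150 nM to 1600 nM.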

Compound 4, half-maximal inhibitory concentration: 900 nM
Beside the measured number, compound 4's estimate is 1.8-fold (0.26 log units) below it, and the stated range covers the measured number.
By their numbers in this assay, from the lowest: compounds 3, 2, 1 and 4 (each within the scatter of the next, the first and the last beyond it).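

In this assay the change gives a 1.8-fold higher number from compound 1 to compound 4 (0.26 log units; within the scatter), the only step shown at this position, on an aromatic carbon para to a large group. Among these compounds, the one earlier step altered a different part of the molecule, so this is the first direct reading here: 4-methylpiperidin-1-yl, a six-membered non-aromatic ring, gives way to acetyl(methyl)amino, which has no ring and fewer heavy atoms and brings in a double bond outside aromatic rings, and the number stays within the scatter. No evidence is available that would explain this result.

The compounds shown leave open how this position responds to other groups in place of 4-methylpiperidin-1-yl, such as a morpholine ring, a carboxylic acid or a longer alkyl chain. On these data alone, it also remains open whether the same swap would stay within the scatter with thiophen-2-yl in place of pyridin-3-yl elsewhere on the shared core.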